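The source may hold more compounds than are shown below. What is called first, only, known or untested is meant among the compounds shown, and "the series" means these compounds.

Measured compounds:
Compound 1 `CCCS(=O)(=O)Nc1ccc(F)c(C(=O)c2n[nH]c3ncc(-c4cccc(OC)c4)cc23)c1F` — 6.3%
Compound 2 `CCCS(=O)(=O)Nc1ccc(F)c(C(=O)c2n[nH]c3ncc(-c4cccc(N(C)C)c4)cc23)c1F` — 26%
Compound 3 `CCCS(=O)(=O)Nc1ccc(F)c(C(=O)c2n[nH]c3ncc(-c4ccc(Cl)cc4Cl)cc23)c1F` — 22%

These values come from an assay for binding affinity to dual specificity mitogen-activated protein kinase kinase 4 (Homo sapiens), read by KINOMEscan, tested at 100 nM; on this read-out higher numbers stand for a weaker effect at the one concentration tested and lower numbers for a stronger effect. Compound 2 gives the highest of the three numbers: compound 3 lies nearest, a number 4 percentage points lower from compound 2 to compound 3 (within the scatter), while compound 1 lies furthest, a number 19.7 percentage points higher from compound 1 to compound 2 (beyond the scatter).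

Compound 4 `CCCS(=O)(=O)Nc1ccc(F)c(C(=O)c2n[nH]c3ncc(-c4ccc(C(N)=O)cc4)cc23)c1F` has not yet been measured. Its change from compound 2 is 4-carbamoylphenyl in place of 3-(dimethylamino)phenyl on an aromatic carbon. Among the compounds with values here, the steps that bear on this are those that swap the aryl group at the same place: a number 19.7 percentage points higher from compound 1 to compound 2 (beyond the scatter), a number 15.7 percentage points higher from compound 1 to compound 3 (beyond the scatter), and a number 4 percentage points lower from compound 2 to compound 3 (within the scatter). Such swaps have shifted this assay by at most a modest amount, and the one starting from compound 2 stayed within the scatter. The expected step is therefore a number 6 percentage points lower from compound 2 to compound 4 (within the scatter), small and without a clear direction. Compound 4 is estimated at 20%, within 5% to 45%.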

Compound 4, a percentage reported as activity, at one concentration (the size of the read-out at that concentration, not a potency): 0.15%
Compound 4: the middle estimate sits 19.9 percentage points above what was measured, and the stated range ends above it.
By their numbers in this assay, from the lowest: compounds 4 and 1 (each within the scatter of the next); then compounds 3 and 2 (each within the scatter of the next).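

In this assay 4-carbamoylphenyl on this aromatic carbon gives a number 25.9 percentage points lower from compound 2 to compound 4 (beyond the scatter) and a number 21.9 percentage points lower from compound 3 to compound 4 (beyond the scatter) here, so aryl swaps from compound 2 need not stay small. Against 3-methoxyphenyl the same change gives a number 6.2 percentage points lower from compound 1 to compound 4 (within the scatter) here, so two differently substituted aryl groups share the low end of the read-out. Nothing available here explains this result.

On these data alone, whether the carbamoyl group itself or its place on the phenyl ring carries the change stays open. So does how a 3-carbamoylphenyl, 4-carboxyphenyl or 4-aminophenyl group would read.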